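The source may hold more compounds than are shown below. What is called first, only, known or untested is meant among the compounds shown, and "the series" means these compounds.

Within the data shown here, compound 1 `CCCCCCCCNC(=O)[C@@H](NC(=O)c1ccco1)[C@@H](C)O` gives 200000 nM in a functional assay on SW-620 cells (Homo sapiens) for cytotoxicity, read by MTT assay, with a stated time of 48 h (a higher number here means a weaker inhibitor, a lower number a stronger inhibitor), the higher of the two numbers measured so far. Among the measured compounds shown here, its only neighbour, compound 2 `CCCCCCCCNC(=O)[C@@H](NC(=O)/C=C/c1ccccc1)[C@@H](C)O`, gives 61400 nM in this assay. That step, a 3.3-fold lower number from compound 1 to compound 2 (0.51 log units; beyond the scatter), swapped the group on the carbonyl carbon. Compound 3 `CCCCCCCCCCCCCCCCCCNC(=O)[C@@H](NC(=O)c1ccco1)[C@@H](C)O` differs from compound 1 at another spot: decyl in place of hydrogen on a saturated chain carbon, eight bonds along the chain from an amide-type nitrogen. For the measured compounds named here, no measured step touches this chain, so the data offer no guide to size or direction. Compound 3 is therefore expected to give about 150000 nM, within a range of 40000 nM to 500000 nM. The expected step, a 1.3-fold lower number from compound 1 to compound 3 (0.12 log units; within the scatter), lies within the usual scatter.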

Compound 3, half-maximal inhibitory concentration: > 200000 nM
Compound 3: no number, only a limit (the forecaster's own chance of this, stated with the estimate: 25%); at least 1.3-fold (0.12 log units) between middle value and limit.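

Compound 3 gives > 200000 nM in this assay, which is a limit of the assay and not a number. This shows that decyl in place of hydrogen, the only change to this saturated chain shown here, brings a number no lower from compound 1 to compound 3 (the limit leaves the size open). The size of the step cannot be read: the limit of > 200000 nM in this assay, at which 1 of the 3 values shown sits.

Going by these compounds, it remains open whether the same decyl change would act alike on compound 2. Also open, on these data alone, is what an amine or a carboxylic acid on this chain would give.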